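A few compounds are considered here, and "the series" means these few. Any claim that something is new, unique, unknown or untested is made for them only; others in the source may bear on it.

Measured so far in a functional assay on Hep 3B2 cells (Homo sapiens) for antiproliferative activity, read by MTT assay, with a stated time of 24 h, tested at 1.23 ug/mL; a higher number here means a stronger effect of the compound at the concentration tested, a lower number a weaker effect:
compound 1 `Cc1c(C(=O)Nc2ccc(-c3ccccc3)cc2)nc2ccccc2c1O` gives 14.3%;
compound 2 `Cc1ccc2nc(C(=O)Nc3c(F)cc(-c4cccc(F)c4)cc3F)c(C)c(C(=O)O)c2c1` gives 21.3%.

Compound 1 stands at the smaller of the two numbers, but the gap to compound 2 lies within the usual scatter of this kind of measurement, so no real difference between the two can be claimed. The unmeasured compound 3 `Cc1c(C(=O)Nc2ccc(-c3ccccc3)cc2)nc2ccccc2c1C(=O)O` differs from compound 1 in one place: carboxy in place of hydroxy on an aromatic carbon. Going by the values given here, no step between two measured compounds is available to set the size of this change. In this assay the step is expected to be small, upward at most, and likely not beyond the scatter, because compound 2 also carries a carboxy group and gives 21.3%, which is within the scatter of compound 1. The step from compound 1 to compound 3 is therefore estimated at a number 3.7 percentage points higher from compound 1 to compound 3 (within the scatter). Compound 3 is expected to reach about 18%, in a range from 5% to 35%.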

Compound 3, a percentage reported as inhibition, at one concentration (the size of the read-out at that concentration, not a potency): 1.25%
For compound 3 the middle estimate is 16.8 percentage points above the measured one; measured number outside the range, below it.
By their numbers in this assay, from the lowest: compound 3; then compounds 1 and 2 (each within the scatter of the next).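

In this assay, placing carboxy instead of hydroxy on this aromatic carbon, opposite the ring nitrogen and ortho to a methyl group, gives a number 13.1 percentage points lower from compound 1 to compound 3 (beyond the scatter). This shows that the read-out at this concentration is sensitive to the group held at this position, even though the count of hydrogen-bond donors and acceptors stays the same across the change and neither group carries a net charge. Nothing at hand gives a reason for this fall.

On these data alone, whether an amine or a methyl ester on the same aromatic carbon would stay level with compound 1 or fall as far as compound 3 remains open. Also open, as far as these compounds go, is whether this step keeps its direction and size when other groups are present elsewhere on the core.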